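The compounds below may be only part of what the source reports. "The series", "measured", "known", "first", "only" and "open" are said of these compounds alone.

Measured in an in vitro ADME assay on microsomes from liver (Homo sapiens) for metabolic stability (on this read-out lower numbers stand for slow clearance and higher numbers for fast clearance), so far

- compound 1 `COc1ccc(C(=O)N2CCC(=CC(=O)N[C@@H]3CCN(Cc4ccc5cc(F)ccc5c4)C3)CC2)cc1` gives 252 mL/min/kg
- compound 2 `COc1cccc(C(=O)N2CCC(=CC(=O)N[C@@H]3CCN(Cc4ccc5cc(F)ccc5c4)C3)CC2)c1` gives 500 mL/min/kg
- compound 3 `O=C(C=C1CCN(C(=O)c2ccccc2F)CC1)N[C@@H]1CCN(Cc2ccc3cc(F)ccc3c2)C1` gives 590 mL/min/kg

Compound 3 stands above compound 1, as a 2.3-fold higher number from compound 1 to compound 3 (0.37 log units; beyond the scatter) shows. It cannot be separated from compound 2, as a 1.2-fold higher number from compound 2 to compound 3 (0.07 log units; within the scatter) shows. It therefore shares the upper end of this small set with compound 2.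

The next compound is compound 4 `O=C(C=C1CCN(C(=O)c2ccc(Cl)cc2O)CC1)N[C@@H]1CCN(Cc2ccc3cc(F)ccc3c2)C1`, which keeps the rest of compound 3 and alters one group. The difference is 4-chloro-2-hydroxyphenyl in place of 2-fluorophenyl on a carbonyl carbon and amounts to 4-chloro-2-hydroxyphenyl in place of 2-fluorophenyl on a carbonyl carbon.

All three measured steps are swaps at this same carbonyl carbon. Besides the two above, there is a 2.0-fold higher number from compound 1 to compound 2 (0.30 log units; within the scatter) as the third. The largest of them is modest, and the other two stay within the scatter. For the measured compounds named here, none of the three compounds carries the incoming group, so the data offer no direct precedent for it and no firm direction.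

In this assay a step beyond the scatter is therefore not expected. For compound 4 the expected change is a 1.3-fold lower number from compound 3 to compound 4 (0.12 log units; within the scatter) and this is read as no real shift. The estimated value for compound 4 is 450 mL/min/kg and the expected range runs from 200 mL/min/kg to 900 mL/min/kg in this read-out.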

Compound 4, clearance: 87 mL/min/kg
The estimate for compound 4 lay 5.2-fold (0.71 log units) above the measured number; measured number below the stated range.
By their numbers in this assay, from the lowest: compound 4; then compounds 1, 2 and 3 (each within the scatter of the next, the first and the last beyond it).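

In this assay, this carbonyl carbon proves able to carry a much larger change than the earlier swaps suggested, whose largest step was a 2.3-fold higher number from compound 1 to compound 3 (0.37 log units; beyond the scatter): the new group gives a 6.8-fold lower number from compound 3 to compound 4 (0.83 log units; beyond the scatter), along with a 5.7-fold lower number from compound 2 to compound 4 (0.76 log units; beyond the scatter) and a 2.9-fold lower number from compound 1 to compound 4 (0.46 log units; beyond the scatter). For the compounds shown here, all three new steps lie beyond the scatter, so compound 4 now stands alone at the low end of this set, and 4-chloro-2-hydroxyphenyl is the first group here to bring clearance clearly below that of compound 1, entering with a hydrogen-bond donor and a hydrogen-bond acceptor where the 2-fluorophenyl it replaces has neither. Nothing available here accounts for the size of this drop.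

On these data alone, what stays open is how the step divides between the chlorine and the hydroxy group, as the two enter together, and a 4-chlorophenyl or a 2-hydroxyphenyl on the same carbonyl carbon would begin to separate them. As far as these compounds go, it also remains open whether a different group on the phenyl ring, such as an amine or a carboxylic acid, would give a similar drop in clearance.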